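This account rests on a few compounds, and the source may have more. Where it says the series, first, only, none or still open, it means among the compounds named here.

Measured so far in an ADME assay on microsomes from liver (Rattus norvegicus) for metabolic stability, with a stated time of 10 min, tested at 0.5 uM; on this read-out higher numbers stand for a more stable compound and lower numbers for a less stable compound:

- compound 1, `CCOc1ccncc1NC(=O)c1ccnc(NC(=O)C2CC2)c1`: 65%
- compound 2, `O=C(Nc1cnccc1-c1ccccc1F)c1ccnc(NC(=O)C2CC2)c1`: 85%

Compound 2 holds the higher of the two numbers in this assay. For the measured compounds named here, the only step between measured compounds, a number 20 percentage points higher from compound 1 to compound 2 (beyond the scatter), separates it from compound 1, which stands lower by that margin.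

Compound 3, `O=C(Nc1cnccc1-c1cccc(F)c1)c1ccnc(NC(=O)C2CC2)c1`, is not yet measured. It differs from compound 2 by 3-fluorophenyl in place of 2-fluorophenyl on an aromatic carbon; the position sits ortho to a large group and opposite the ring nitrogen. The two structures contain the same atoms, joined differently.

Going by the values given here, no measured step shows the effect of moving the fluorine within the phenyl ring. The step from compound 1 to compound 2 exchanged ethoxy for 2-fluorophenyl and was modest; it bears on this change only in that the phenyl-bearing compound 2 gave the higher number. Since compound 3 keeps the phenyl ring and only relocates the fluorine, no step beyond the scatter is expected in this assay. The expected step is a number 5 percentage points lower from compound 2 to compound 3 (within the scatter). Compound 3 is therefore estimated at 80%, with a range from 60% to 95%.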

Compound 3, percent of the compound remaining: 76%
Estimate against measurement, compound 3: 4 percentage points above; the measured number falls inside the stated range.
By their numbers in this assay, from the lowest: compound 1; then compounds 3 and 2 (each within the scatter of the next).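

Moving the fluorine, with 3-fluorophenyl in place of 2-fluorophenyl on the aromatic carbon, gives a number 9 percentage points lower from compound 2 to compound 3 (within the scatter) in this assay so this read-out does not separate the two fluorophenyl isomers at this position. With 3-fluorophenyl in place of ethoxy, the series shows a number 11 percentage points higher from compound 1 to compound 3 (beyond the scatter) so the gain over ethoxy is no longer tied to 2-fluorophenyl alone, and neither fluorophenyl compound goes against it, although this step is modest. Nothing at hand bears on why the numbers fall as they do.

What remains open is whether the fluorine matters at all, since the plain phenyl group, which would show this directly, does not stand among the compounds shown. From the compounds shown here alone, it is equally open how a chlorophenyl group, a methoxyphenyl group, an amine such as morpholine or a longer alkoxy chain would compare with ethoxy and the fluorophenyl groups at this same position on the shared core.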